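A few compounds are considered here, and "the series" means these few. Any claim that something is new, unique, unknown or untested is made for them only; others in the source may bear on it.

Measured compounds: compound 1 `CN1[C@@H]2c3[nH]c4ccccc4c3C[C@H]1[C@H](C#N)N1[C@@H](CNC(=O)c3ccc(F)cc3)c3[nH]c4ccccc4c3C[C@@H]21` gives 140 nM in a functional assay on HCT-116 cells (Homo sapiens) for cytotoxicity, read by MTT assay, with a stated time of 72 h; a higher number here means a weaker inhibitor, a lower number a stronger inhibitor; compound 2 `CN1[C@@H]2c3[nH]c4ccccc4c3C[C@H]1[C@H](C#N)N1[C@@H](CNC(=O)c3cc4ccccc4[nH]3)c3[nH]c4ccccc4c3C[C@@H]21` gives 880 nM.

Compound 2 stands with the highest number of the two measured, above compound 1 by a 6.3-fold higher number from compound 1 to compound 2 (0.80 log units; beyond the scatter). Compound 3 `COc1ccc(/C=C/C(=O)NC[C@H]2c3[nH]c4ccccc4c3C[C@H]3[C@H]4c5[nH]c6ccccc6c5C[C@@H]([C@H](C#N)N23)N4C)cc1` is not yet measured; it differs from compound 2 by 2-(4-methoxyphenyl)ethenyl in place of 1H-indol-2-yl on a carbonyl carbon. Going by the values given here, no measured step covers this exact change; the only step, the swap of aryl groups on the same carbonyl carbon, is a 6.3-fold higher number from compound 1 to compound 2 (0.80 log units; beyond the scatter), which shows that changes at this carbonyl carbon can move this assay beyond the scatter in either direction. For compound 3 a lower number than compound 2 is expected, estimated at 400 nM (range 100 nM to 2000 nM), a step of a 2.2-fold lower number from compound 2 to compound 3 (0.34 log units; beyond the scatter) from compound 2.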

Compound 3, half-maximal inhibitory concentration: 5060 nM
Compound 3: the middle estimate sits 13-fold (1.10 log units) below what was measured, and the stated range ends below it.
By their numbers in this assay, from the lowest: compound 1; then compound 2; then compound 3.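

In this assay placing 2-(4-methoxyphenyl)ethenyl on the carbonyl carbon gives a 5.8-fold higher number from compound 2 to compound 3 (0.76 log units; beyond the scatter) and a 36-fold higher number from compound 1 to compound 3 (1.56 log units; beyond the scatter) in the series. This place therefore spans a wider range than the first pair showed, and compound 3 has the highest number of the three, with 4-fluorophenyl in compound 1 still the lowest. Nothing available explains the rise in number.

On these data alone, whether the ethenyl link or the methoxy group carries the change stays open, and 4-methoxyphenyl directly on the carbonyl carbon would separate the two. How a saturated ethyl link or an amine on the aryl ring would read here is also unknown.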